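Swapping the Amide Aryl Group for a Nitrophenyl

The compounds below may be only part of what the source reports. "The series", "measured", "known", "first", "only" and "open" are said of these compounds alone.

Compound 1 `O=C(Nc1cccc(-c2oc3cc(-c4ccc(F)cc4)ccc3c(=O)c2O)c1)c1ccc(F)cc1`: 16000 nM
Compound 2 `O=C(Nc1cccc(-c2oc3cc(-c4ccc(F)cc4)ccc3c(=O)c2O)c1)c1ccc(C(F)(F)F)cc1`: 29400 nM
Compound 3 `Cc1cc(C)cc(C(=O)Nc2cccc(-c3oc4cc(-c5ccc(F)cc5)ccc4c(=O)c3O)c2)c1`: 11900 nM

In a functional assay on MDA-MB-231 cells (Homo sapiens) for antiproliferative activity, read by CCK-8 assay, with a stated time of 72 h (a higher number here means a weaker inhibitor, a lower number a stronger inhibitor), compound 3 gives the lowest of the three numbers, though the step of a 1.3-fold lower number from compound 1 to compound 3 (0.13 log units; within the scatter) stays within the scatter, while the step of a 2.5-fold lower number from compound 2 to compound 3 (0.39 log units; beyond the scatter) goes beyond it. Compound 4 `O=C(Nc1cccc(-c2oc3cc(-c4ccc(F)cc4)ccc3c(=O)c2O)c1)c1ccc([N+](=O)[O-])cc1` is not yet measured; it differs from compound 3 in one place: 4-nitrophenyl in place of 3,5-dimethylphenyl on a carbonyl carbon. The measured steps that bear on this change are those that exchange the aryl group on the carbonyl: a 1.8-fold higher number from compound 1 to compound 2 (0.26 log units; within the scatter) and a 2.5-fold lower number from compound 2 to compound 3 (0.39 log units; beyond the scatter). Both were small, and all three measured values sit in a narrow band of weak inhibition. A step of similar size toward a higher number is expected, a 1.7-fold higher number from compound 3 to compound 4 (0.23 log units; within the scatter). Compound 4 is therefore estimated at 20000 nM, with a range from 8000 nM to 50000 nM.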

Compound 4, half-maximal inhibitory concentration: 14700 nM
For compound 4 the middle estimate is 1.4-fold (0.13 log units) above the measured one; low and high end bracket the measured number.
By their numbers in this assay, from the lowest: compounds 3, 4, 1 and 2 (each within the scatter of the next, the first and the last beyond it).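

In this assay, 4-nitrophenyl on the carbonyl carbon gives a number that cannot be told apart from those of its neighbours: a 1.2-fold higher number from compound 3 to compound 4 (0.09 log units; within the scatter), a 1.1-fold lower number from compound 1 to compound 4 (0.04 log units; within the scatter) and a 2.0-fold lower number from compound 2 to compound 4 (0.30 log units; within the scatter). Adding nitrogen and oxygen atoms to this aryl group therefore produces no step beyond the scatter, so the only such step among the four compounds remains that between compound 2 and compound 3. Nothing available gives a reason for this flat result. Going by these compounds, whether an amine or a carboxylic acid on this ring, or a longer chain in its place, would shift the number remains open.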